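A few compounds are considered here, and "the series" means these few. Any claim that something is new, unique, unknown or untested is made for them only; others in the source may bear on it.

Within the data shown here, in a functional assay on a cell-free system (plasma, Oryctolagus cuniculus) for inhibition, with stated times of 5 min, 1 min and 6 min (a higher number here means a weaker inhibitor, a lower number a stronger inhibitor), compound 1 `CCOC(=O)c1c(C)nc(-c2cccc(C#N)c2)n1OCc1ccccc1` gives 5930 nM and compound 2 `CCOC(=O)c1c(C)nc(-c2cccc(C#N)c2)n1OCc1ccc(OC)cc1` gives 6830 nM, so compound 2 stands within the scatter of the only other measured compound. Compound 3 `CCOC(=O)c1c(C)nc(-c2cccc(C#N)c2)n1OCc1ccc(C#N)cc1` carries cyano in place of methoxy on an aromatic carbon, para to a large group: cyano in place of methoxy on an aromatic carbon. Among the measured compounds shown here, one measured step bears on this place: a 1.2-fold higher number from compound 1 to compound 2 (0.06 log units; within the scatter), with methoxy in place of hydrogen. Nothing beyond the scatter is therefore expected in this assay, and no direction is favoured. The expected step is a 1.1-fold lower number from compound 2 to compound 3 (0.06 log units; within the scatter). For compound 3 the estimated value is 6000 nM, with an expected range of 2500 nM to 14000 nM.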

Compound 3, half-maximal inhibitory concentration: 4240 nM
Compound 3: the middle estimate sits 1.4-fold (0.15 log units) above what was measured; the range from low to high includes it.
By their numbers in this assay, from the lowest: compounds 3, 1 and 2 (each within the scatter of the next).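

Cyano at this aromatic carbon, para to a large group, stays within the scatter of methoxy (a 1.6-fold lower number from compound 2 to compound 3 (0.21 log units; within the scatter)) and of hydrogen (a 1.4-fold lower number from compound 1 to compound 3 (0.15 log units; within the scatter)) in this assay. All three groups tried at this place therefore give values within the scatter of one another, including the change from 4-methoxybenzyl to 4-cyanobenzyl. No measurement bears on the reason for this. From the compounds shown here alone, whether an amine, a carboxylic acid or a longer chain at this place would give a step beyond the scatter remains open.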